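Alkyl and amino variation on the shared core of compound 1

The source may hold more compounds than are shown below. What is called first, only, known or untested is meant among the compounds shown, and "the series" means these compounds.

Measured compounds:
- compound 1, `Cc1cc(-c2cc(N3C[C@H](O)[C@@H](O)C3)ccc2O)nc(N)n1`: 900 nM
- compound 2, `Nc1nc(-c2cc(N3C[C@H](O)[C@@H](O)C3)ccc2O)cc(C2CCCCC2)n1`: 1200 nM
- compound 3, `CN(C)c1cc(-c2cc(N3C[C@H](O)[C@@H](O)C3)ccc2O)nc(N)n1`: "not determined" (no result reported)

All three share the same core and differ only in the group on the aromatic carbon next to the ring nitrogen. In a functional assay on EJ cells (Homo sapiens) for cytotoxicity, with a stated time of 48 h (a higher number here means a weaker inhibitor of growth, a lower number a stronger inhibitor of growth), compound 1 gives 900 nM and compound 2 gives 1200 nM. The step of a 1.3-fold higher number from compound 1 to compound 2 (0.12 log units; within the scatter) shows that replacing methyl with cyclohexyl at this position changes nothing beyond the scatter. For compound 3, which carries a dimethylamino group at the same place, this assay reports "not determined" (no result reported), so compound 3 stands without a number and gives no anchor of its own.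

Compound 4, `CCc1cc(-c2cc(N3C[C@H](O)[C@@H](O)C3)ccc2O)nc(N)n1`, is the next member. Its difference from compound 3 is ethyl in place of dimethylamino on an aromatic carbon. Among the measured compounds shown here, no measured step involves an amino group leaving this position, so the only bearing information is the methyl-to-cyclohexyl step between compound 1 and compound 2, which was within the scatter. Ethyl sits between methyl and cyclohexyl in size, so compound 4 is expected to behave like compound 1 and compound 2 in this assay, with no step beyond the scatter in either direction. Compound 4 is therefore estimated at 1000 nM, with a range from 400 nM to 2500 nM.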

Compound 4, concentration for 50% growth inhibition: 1500 nM
For compound 4 the middle estimate is 1.5-fold (0.18 log units) below the measured one, within the range that was stated.
By their numbers in this assay, from the lowest: compounds 1, 2 and 4 (each within the scatter of the next).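

In this assay, ethyl can now be read against both other alkyl groups on the aromatic carbon next to the ring nitrogen: the change from cyclohexyl to ethyl gives a 1.3-fold higher number from compound 2 to compound 4 (0.10 log units; within the scatter), and the change from methyl to ethyl gives a 1.7-fold higher number from compound 1 to compound 4 (0.22 log units; within the scatter). Among the compounds shown here, with methyl, ethyl and cyclohexyl all in hand, every step among compounds 1, 2 and 4 lies within the scatter, so this small set does not separate the three alkyl groups, although the earlier pair alone offered only a single comparison. No supporting measurement is available to explain this flat reading.

The numbers shown at this position belong to alkyl groups only, so how a primary amine, a carboxylic acid or a phenyl ring would read here stays open, and compound 3 gives no number that could settle the amino case. Also open, from the compounds shown here alone, is whether the flat reading extends to a longer chain such as n-hexyl, or to a chain carrying a hydroxyl group.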